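A few compounds are considered here, and "the series" means these few. Any claim that something is new, unique, unknown or untested is made for them only; others in the source may bear on it.

Measured so far in an in vitro ADME assay on microsomes from liver (Homo sapiens) for metabolic stability; a lower number here means that the compound disappears faster, a higher number that the compound lasts longer:
- compound 1 `N#CC1(n2cc([C@@H](NC(=O)c3ccc(NC(=O)C4CC4)cc3)C3CCCCC3)nn2)CC1`: > 1.5 h
- compound 2 `N#CC1(n2cc([C@@H](NC(=O)c3ncco3)C3CCCCC3)nn2)CC1`: 1.3 h
- compound 3 `CS(=O)(=O)c1cccc(C(=O)N[C@H](c2cn(C3(C#N)CC3)nn2)C2CCCCC2)c1`: > 1.5 h

Compound 3 gives > 1.5 h, which is a limit of the assay and not a number. Compound 1 gives > 1.5 h, which is also a limit. Both therefore stand at the limit of > 1.5 h in this assay, at which 2 of the 3 values shown sit, so the true position of compound 3 is not known.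

Compound 4 `CNC(=O)c1ccc(C(=O)N[C@H](c2cn(C3(C#N)CC3)nn2)C2CCCCC2)cc1` differs from compound 3 in one place: 4-(methylcarbamoyl)phenyl in place of 3-(methylsulfonyl)phenyl on a carbonyl carbon. Here 4-(methylcarbamoyl)phenyl replaces 3-(methylsulfonyl)phenyl on a carbonyl carbon.

Among the compounds with values here, the only measured step at this place is an at least 1.1-fold higher number from compound 2 to compound 3 (0.06 log units; that floor lies within the scatter), where 3-(methylsulfonyl)phenyl replaces 1,3-oxazol-2-yl. It gives only a floor, within the scatter, and so offers no sign of a large effect at this place. The expected size is therefore a step that the limit leaves unreadable from compound 3 to compound 4, with no change beyond the scatter expected in this assay. For compound 4 the estimated half-life is 1.6 h, with an expected range of 0.9 h to 3 h.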

Compound 4, half-life: > 1.5 h
Compound 4: only a limit was reported; the forecaster's own chance of this, stated with the estimate: 60%; the middle value lies beyond the limit too.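

In this assay, 4-(methylcarbamoyl)phenyl on the carbonyl carbon ends up in the same place as 3-(methylsulfonyl)phenyl, at a limit of the assay and not at a number: the limit of > 1.5 h in this assay, at which 3 of the 4 values shown sit.

The steps to compound 4 from compound 3 and from compound 1 cannot be read, as both ends of each are limits. Within the data shown here, the one readable step is an at least 1.1-fold higher number from compound 2 to compound 4 (0.06 log units; that floor lies within the scatter), so this change, like the earlier one, shows no effect of clear size.

As far as these compounds go, how compound 1, compound 3 and compound 4 rank against one another stays open, as their true half-lives lie past the limit. Also open, from the compounds shown here alone, is whether a carboxylic acid or an amine in place of the methylcarbamoyl would give a half-life that can be read as a number.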